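A few compounds are considered here, and "the series" means these few. Any claim that something is new, unique, unknown or untested is made for them only; others in the source may bear on it.

Compound 2 `CCCc1[nH]c2ccc(Cl)cc2c1C1=CCNCC1` sits, in an in vitro assay on HEK293 cells for displacement of a labelled ligand from 5-hydroxytryptamine receptor 6 (Homo sapiens) (on this read-out higher numbers stand for weaker inhibition and lower numbers for stronger inhibition), at 40 nM, and compound 1 `CCc1[nH]c2ccc(Cl)cc2c1C1=CCNCC1` gives 30 nM in the same assay, so the two numbers lie within the usual scatter of each other: the step of a 1.3-fold higher number from compound 1 to compound 2 (0.12 log units; within the scatter) confirms this. Compound 3 `CC(C)c1[nH]c2ccc(Cl)cc2c1C1=CCNCC1` differs from compound 2 by isopropyl in place of propyl on an aromatic carbon. Among the compounds with values here, the only measured step that bears on a change at this aromatic carbon is the one from compound 1 to compound 2, and it was within the scatter, so no step beyond the scatter is expected here either; the expected step is a 1.1-fold higher number from compound 2 to compound 3 (0.05 log units; within the scatter). Compound 3 is therefore estimated at 45 nM, in the range 15 nM to 140 nM.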

Compound 3, half-maximal inhibitory concentration: 100 nM
Beside the measured number, compound 3's estimate is 2.2-fold (0.35 log units) below it; the range from low to high includes it.
By their numbers in this assay, from the lowest: compounds 1 and 2 (each within the scatter of the next); then compound 3.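

In this assay, rearranging the same atoms from propyl to isopropyl gives a 2.5-fold higher number from compound 2 to compound 3 (0.40 log units; beyond the scatter), so at this aromatic carbon the arrangement of the chain matters and not only its atom count. A methyl on the saturated chain carbon bound to the aromatic carbon gives a 3.3-fold higher number from compound 1 to compound 3 (0.52 log units; beyond the scatter), whereas the earlier methyl two bonds along the chain stayed within the scatter. No measured evidence accounts for this difference. On these data alone, whether a cyclopropyl or tert-butyl group here would extend the trend remains open, as does how a longer chain would compare.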